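Chloro to cyano on the shared benzimidazole-type core

The compounds below may be only part of what the source reports. "The series", "measured", "known", "first", "only" and "open" are said of these compounds alone.

Measured in an assay on V79 cells for inhibition of cytochrome P450 11B1, mitochondrial (Homo sapiens), read by HTRF, with a stated time of 1 h; on this read-out lower numbers stand for stronger inhibition and higher numbers for weaker inhibition:
compound 1 `N#Cc1cc2c(cc1F)nc(-c1cccnc1)n2C1CC1`: 117 nM
compound 2 `Fc1ccc2nc(-c3cccnc3)n(C3CC3)c2c1`: 401 nM
compound 3 `Clc1ccc2nc(-c3cccnc3)n(C3CC3)c2c1`: 477 nM

Compound 3 gives the highest of the three numbers in this assay, with compound 2 nearest and compound 1 furthest. Going by the values given here, the only directly measured step, a 1.2-fold higher number from compound 2 to compound 3 (0.08 log units; within the scatter), stays within the scatter. Compound 4 `N#Cc1ccc2nc(-c3cccnc3)n(C3CC3)c2c1` arises from compound 3 by the change (cyano in place of chloro on an aromatic carbon). Among the compounds with values here, no measured step covers this exchange; compound 1, which carries a cyano group together with fluoro, sits well below compound 2, which carries fluoro alone, but that comparison is not a single-place step. A lower number for compound 4 in this assay is therefore expected, amounting to a 2.4-fold lower number from compound 3 to compound 4 (0.38 log units; beyond the scatter). The estimate for compound 4 is 200 nM, within 80 nM to 500 nM.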

Compound 4, half-maximal inhibitory concentration: 374 nM
Estimate against measurement, compound 4: 1.9-fold (0.27 log units) below; the range from low to high includes it.
By their numbers in this assay, from the lowest: compound 1; then compounds 4, 2 and 3 (each within the scatter of the next).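

At this aromatic carbon, cyano in place of chloro gives [ a 1.3-fold lower number from compound 3 to compound 4 (0.11 log units; within the scatter) ] and cyano in place of fluoro gives [ a 1.1-fold lower number from compound 2 to compound 4 (0.03 log units; within the scatter) ], so this assay does not separate these three groups here. The fluoro of compound 1 marks the larger difference: hydrogen in place of that fluoro gives [ a 3.2-fold higher number from compound 1 to compound 4 (0.50 log units; beyond the scatter) ], so cyano alone does not account for the low number of compound 1. Nothing available explains either result. The compounds shown leave open whether an amine or a carboxylic acid on this carbon would separate from these groups. They also leave open whether fluoro would have the same effect alongside chloro as alongside cyano.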